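Methylsulfonyl replacing methyl on the benzylidene aryl ring

The source may report more compounds than this note shows. Statements on the series, on what has been measured and on what is new or still open speak of the compounds shown alone.

Three compounds of the series have been run in a functional assay on the whole organism (strain Kunming) for inhibition, with Mus musculus as the target, in the writhing test, with stated times of 1 h and 15 min, at a dose of 200 mg/kg by the oral route; a lower number here means less inhibition, a higher number more inhibition at the dose given (going by the name of the read-out). Compound 1 `CN(CC1CCC/C(=C\c2ccccc2)C1=O)c1ccccc1` gives 69.7%. Compound 2 `Cc1ccc(/C=C2\CCCC(CN(C)c3ccccc3)C2=O)cc1` gives 68.2%, and compound 3 `Cc1ccc(/C=C2\CCCC(CN(C)c3cccc(C)c3)C2=O)cc1` gives 75.8%. Compound 2 holds the lowest of the three numbers, but neither gap separates it from the others: a number 1.5 percentage points lower from compound 1 to compound 2 (within the scatter), and a number 7.6 percentage points higher from compound 2 to compound 3 (within the scatter), both within the scatter.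

Compound 4 `CN(CC1CCC/C(=C\c2ccc(S(C)(=O)=O)cc2)C1=O)c1ccccc1` is the next member to be measured in this assay. Its relation to compound 2 is methylsulfonyl in place of methyl on an aromatic carbon. The group entering sits para to a large group on the aryl ring that carries the exocyclic double bond.

Of the measured steps, both concern a methyl entering on an aromatic carbon in place of hydrogen, and neither moved the read-out beyond the scatter. Among the measured compounds shown here, no measured step concerns methylsulfonyl, so the bearing of the prior steps on compound 4 is indirect: they only show that changes on aromatic carbons of this series have so far left the inhibition where it was. On that basis a step of a number 1.2 percentage points lower from compound 2 to compound 4 (within the scatter) is expected, which is to say no step beyond the scatter in either direction. Compound 4 is therefore estimated to give 67%, with a range from 52% to 80%.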

Compound 4, a percentage reported as inhibition, in the whole organism at one dose (the size of the read-out at that dose, not a potency): 81%
Compound 4: the middle estimate sits 14 percentage points below what was measured; measured number outside the range, above it.
By their numbers in this assay, from the lowest: compounds 2, 1, 3 and 4 (each within the scatter of the next, the first and the last beyond it).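

In this assay, among the compounds shown here, this aromatic carbon, para to a large group, is the first place where a change moves the read-out beyond the scatter, with methylsulfonyl in place of hydrogen giving a number 11.3 percentage points higher from compound 1 to compound 4 (beyond the scatter) and methylsulfonyl in place of methyl giving a number 12.8 percentage points higher from compound 2 to compound 4 (beyond the scatter) in the same direction. Methyl on the same carbon gave only a number 1.5 percentage points lower from compound 1 to compound 2 (within the scatter) so the position does respond to what it carries, though so far the modest rise rests on methylsulfonyl in this one compound. Nothing at hand accounts for the difference between the two groups.

As far as these compounds go, it remains open whether the rise is particular to methylsulfonyl or is shared by other groups at this carbon, such as a sulfonamide, a carboxylic acid, a nitrile or a longer chain on the sulfur. Also open, from the compounds shown here alone, is whether methylsulfonyl has the same effect alongside the extra methyl on the other aromatic ring of compound 3, which differs from compound 4 in more than one place and so allows no direct comparison.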